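This account rests on a few compounds, and the source may have more. Where it says the series, first, only, none or still open, it means among the compounds named here.

Measured compounds:
compound 1, `COc1ccc(-c2c(C#N)c(-c3ccccc3)nc3c2c(-c2ccccc2)nn3-c2ccccc2)cc1OC`, gives > 25000 nM
compound 2, `COc1cc(-c2c(C#N)c(-c3cccs3)nc3c2c(-c2ccccc2)nn3-c2ccccc2)ccc1O`, gives 37300 nM

Going by the values given here, in a functional assay on CCRF-CEM cells (Homo sapiens) for antiproliferative activity, read by resazurin assay, with a stated time of 72 h (on this read-out higher numbers stand for weaker inhibition and lower numbers for stronger inhibition), compound 2 gives 37300 nM, the only value here that is an actual number. Compound 1 gives > 25000 nM, which is a limit of the assay and not a number; (the limit of > 25000 nM in this assay, at which 1 of the 2 values shown sits). Compound 3, `COc1cc(-c2c(C#N)c(-c3ccccc3)nc3c2c(-c2ccccc2)nn3-c2ccccc2)ccc1O`, has not yet been measured in this assay. It differs from compound 2 in one place: phenyl in place of thiophen-2-yl on an aromatic carbon. Both measured compounds show weak inhibition of cell growth, so the step is expected to leave compound 3 in that same weak range, with a change that is expected to stay within the scatter, a 1.1-fold lower number from compound 2 to compound 3 (0.03 log units; within the scatter). The estimate for compound 3 in this assay is 35000 nM, with a range from 15000 nM to 80000 nM.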

Compound 3, half-maximal inhibitory concentration: > 50000 nM
Compound 3: a limit, no number (the forecaster's own chance of this, stated with the estimate: 50%); middle value at least 1.4-fold (0.15 log units) from the limit.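

In this assay, putting phenyl in place of thiophen-2-yl on the aromatic carbon next to the ring nitrogen gives an at least 1.3-fold higher number from compound 2 to compound 3 (0.12 log units; that floor lies within the scatter). Compound 3 stands at a limit of the assay and not at a number, so only a floor for this step can be given: the limit of > 50000 nM in this assay, at which 1 of the 3 values shown sits. Neither of these two aromatic rings at this position gives strong inhibition of cell growth, while the step that swaps hydrogen for methyl on an oxygen, from compound 1 to compound 3, cannot be read, as both of its values are limits.

From the compounds shown here alone, whether an amine, a carboxylic acid or a longer chain at this position would bring a measurable gain stays open. Also open, going by these compounds, is whether changes elsewhere on the shared core would move the number into a stronger range.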